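A few compounds are considered here, and "the series" means these few. Any claim that something is new, unique, unknown or untested is made for them only; others in the source may bear on it.

Of the compounds shown here, three that share one core have been measured in a functional assay on HEK293 cells for agonist activity at Glucose-dependent insulinotropic receptor (Homo sapiens), read by reporter gene assay and cAMP accumulation, with a stated time of 6 h; on this read-out lower numbers stand for an effect already at smaller amounts and higher numbers for an effect only at larger amounts of compound. Compound 1 `CN(C)C(=O)C1CCN(c2nc(-c3cc(F)c(Cl)cc3F)nc3c2CS(=O)(=O)C3)CC1` gives 350 nM. Compound 2 `NC(=O)CC1CCN(c2nc(-c3cc(F)c(Cl)cc3F)nc3c2CS(=O)(=O)C3)CC1` gives 8.3 nM, and compound 3 `O=S1(=O)Cc2nc(-c3cc(F)c(Cl)cc3F)nc(N3CCC(O)CC3)c2C1` gives 14 nM. Among these three numbers compound 3 holds the second highest; the step of a 1.7-fold higher number from compound 2 to compound 3 (0.23 log units; within the scatter) lies within the scatter, while the step of a 25-fold lower number from compound 1 to compound 3 (1.40 log units; beyond the scatter) lies beyond it. Compound 4 `NC(=O)CCC1CCN(c2nc(-c3cc(F)c(Cl)cc3F)nc3c2CS(=O)(=O)C3)CC1` has not yet been measured; it differs from compound 3 in one place: 2-carbamoylethyl in place of hydroxy on a saturated ring carbon. The measured step that bears most on this change is a 1.7-fold higher number from compound 2 to compound 3 (0.23 log units; within the scatter): it compares hydroxy with carbamoylmethyl on a saturated ring carbon and shows no change beyond the scatter. The large step of a 42-fold lower number from compound 1 to compound 2 (1.62 log units; beyond the scatter) shows that dimethylcarbamoyl gives a much higher number than carbamoylmethyl, but compound 4 carries 2-carbamoylethyl, not dimethylcarbamoyl. The step of a 1.2-fold lower number from compound 3 to compound 4 (0.07 log units; within the scatter) is therefore expected to stay within the scatter. Compound 4 is estimated at 12 nM, with a range from 4 nM to 40 nM.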

Compound 4, effective concentration (reported as EC, without a stated level of effect): 18 nM
Compound 4: middle estimate off by 1.5-fold (0.18 log units), on the low side; the measured number falls inside the stated range.
By their numbers in this assay, from the lowest: compounds 2, 3 and 4 (each within the scatter of the next, the first and the last beyond it); then compound 1.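

In this assay, this saturated ring carbon accepts the much larger 2-carbamoylethyl in place of hydroxy without a change beyond the scatter (a 1.3-fold higher number from compound 3 to compound 4 (0.11 log units; within the scatter)), so the size of the group entering here matters little across this pair. Lengthening the chain that carries the unsubstituted amide has a small but real cost (a 2.2-fold higher number from compound 2 to compound 4 (0.34 log units; beyond the scatter)), which the earlier compounds could not show. The 2-carbamoylethyl group also stays far from the high number of the dimethylcarbamoyl group (a 19-fold lower number from compound 1 to compound 4 (1.29 log units; beyond the scatter)), so a longer chain at this position is not what gives a high number.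

Still open, on these data alone, is whether a longer amide chain, a carboxylic acid or an amine at the chain end, or a dimethylated amide on the 2-carbamoylethyl chain would keep the number this low. Nothing shown explains why these numbers differ.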